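This account rests on a few compounds, and the source may have more. Where it says the series, first, only, none or still open, it means among the compounds named here.

Measured so far:
Compound 1 `COc1cc(/C=C/c2ccc(C(C)C)cc2)cc(OC)c1OC`: 6.8 uM
Compound 2 `COc1cc(/C=C/c2ccc(C(C)(C)C)cc2)cc(OC)c1OC`: > 25 uM
Compound 3 `CCOc1ccc(/C=C\c2cc(OC)c(OC)c(OC)c2)cc1`: 1.8 uM

In a functional assay on HT-29 cells (Homo sapiens) for cytotoxicity (a higher number here means that more compound is needed for the effect, a lower number that less compound is needed), compound 1 gives 6.8 uM. For compound 2 the result is only a limit of the assay, > 25 uM, as noted in the limit of > 25 uM in this assay, at which 1 of the 3 values shown sits. Compound 3 gives 1.8 uM, the lowest of the two numbers, and the difference between the core of compound 3 and the core of compound 1 is not broken down here.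

The change from compound 1 to compound 2 is methyl in place of hydrogen on a saturated chain carbon bound to an aromatic carbon and two saturated chain carbons, and it brought an at least 3.6-fold higher number from compound 1 to compound 2 (0.56 log units; beyond the scatter). Compound 4 `CCCOc1ccc(/C=C\c2cc(OC)c(OC)c(OC)c2)cc1` carries the same kind of change relative to compound 3, namely (methyl in place of hydrogen on a saturated chain carbon, two bonds along the chain from an oxygen on an aromatic ring); the place differs, since in compound 1 the carbon is bound to an aromatic carbon and two saturated chain carbons, whereas in compound 3 it sits two bonds along the chain from an oxygen on an aromatic ring.

Because an at least 3.6-fold higher number from compound 1 to compound 2 (0.56 log units; beyond the scatter) points toward a higher number, compound 4 is estimated at 3.2 uM, between 1.2 uM and 9 uM. The step this estimate means, a 1.8-fold higher number from compound 3 to compound 4 (0.25 log units; within the scatter), is expected to be smaller than the earlier one, since the earlier one rests on a single limit.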

Compound 4, concentration for half-maximal effect: 2.8 uM
Compound 4: middle estimate off by 1.1-fold (0.06 log units), on the high side; measured number inside the range.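

In this assay, the added methyl on the core of compound 3 gives a 1.6-fold higher number from compound 3 to compound 4 (0.19 log units; within the scatter), so going from ethoxy to propoxy leaves the number within the scatter on this core. Compared with the earlier step, which falls at a different place on a different core, the result reads as follows: the same change on two cores in this assay, an at least 3.6-fold higher number (0.56 log units; beyond the scatter) from compound 1 to compound 2 and a 1.6-fold higher number (0.19 log units; within the scatter) from compound 3 to compound 4; the limit leaves it open whether they differ. Compound 2 stands at > 25 uM, which is a limit of the assay and not a number, so the series shows that the same kind of change was beyond the scatter on one core and within it on the other, but it does not show whether the size of the change carries over from one core to the other.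

The compounds shown leave open what a longer chain, such as butoxy, would do on the core of compound 3. They also leave open whether a hydroxyl or an amine in place of propoxy would move the number beyond the scatter.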